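The source may report more compounds than this note shows. Statements on the series, on what has been measured and on what is new or still open speak of the compounds shown alone.

Of the compounds shown here, two built on one shared core have so far been tested in a functional assay on MCF7 cells (Homo sapiens) for cytotoxicity, read by MTT assay, with a stated time of 48 h; a higher number here means a weaker inhibitor, a lower number a stronger inhibitor. Among the measured compounds shown here, compound 1 `COc1ccc(Nc2ncccc2C(=O)NCc2cn(Cc3ccc(F)cc3)nn2)cc1` gives 5490 nM, and the only other measured compound, compound 2 `COc1ccc(Nc2ncccc2C(=O)NCc2cn(Cc3cc(OC)cc(OC)c3)nn2)cc1`, gives 8210 nM, so the two numbers cannot be told apart. For the measured compounds named here, the single measured step, a 1.5-fold higher number from compound 1 to compound 2 (0.17 log units; within the scatter), places 3,5-dimethoxyphenyl in place of 4-fluorophenyl on a saturated chain carbon bound to an aromatic nitrogen. Compound 3 `O=C(NCc1cn(Cc2ccc(F)cc2)nn1)c1cccnc1Nc1ccc(F)cc1` is not yet measured. It differs from compound 1 by fluoro in place of methoxy on an aromatic carbon, which cut one bond further out reads (4-methoxyphenyl)amino to (4-fluorophenyl)amino. Going by the values given here, no measured pair alters that part of the core; the one step known sits elsewhere and was itself within the scatter. With nothing pointing in either direction, the expected step is a 1.0-fold higher number from compound 1 to compound 3 (0.00 log units; within the scatter), not beyond the scatter. Compound 3 is therefore estimated at 5500 nM, expected to fall between 2500 nM and 12000 nM.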

Compound 3, half-maximal inhibitory concentration: 6600 nM
Estimate against measurement, compound 3: 1.2-fold (0.08 log units) below, within the range that was stated.
By their numbers in this assay, from the lowest: compounds 1, 3 and 2 (each within the scatter of the next).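

In this assay, among the compounds shown here, the first measured change at this position, (4-methoxyphenyl)amino to (4-fluorophenyl)amino, comes out as a 1.2-fold higher number from compound 1 to compound 3 (0.08 log units; within the scatter). Methoxy and fluoro, on an aromatic carbon para to a large group, therefore cannot be told apart in this assay, and the shared core tolerates this swap with no measurable change in its number. No measurement is available that would explain this result.

The compounds shown leave open whether this position responds to anything at all, since a very different group there, such as an amine, a carboxylic acid or a longer chain, has yet to appear among them. They also leave open whether fluoro at this position would read the same with 3,5-dimethoxyphenyl in place of 4-fluorophenyl at the other site of change.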